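The source may report more compounds than this note shows. Statements on the series, on what has been measured and on what is new or still open speak of the compounds shown alone.

Compound 1 `CNC(=O)c1cccnc1NCCCN1CCN(c2ccccc2OC)CC1` and compound 2 `CN(C)C(=O)c1cccnc1NCCCN1CCN(c2ccccc2C#N)CC1` share a common core and were both measured for a functional assay for antagonist activity at Alpha-1A adrenergic receptor (Oryctolagus cuniculus); on this read-out higher numbers stand for weaker binding and lower numbers for tighter binding. In this assay compound 1 gives 1 nM, and compound 2 gives 2 nM, the larger of the two numbers, though the two lie within the scatter of each other. Compound 3 `CCCc1ccccc1N1CCN(CCCNc2ncccc2C(=O)N(C)C)CC1` has not yet been measured and differs from compound 2 by propyl in place of cyano on an aromatic carbon. Among the measured compounds shown here, no measured pair shows this change, so the step from compound 2 to compound 3 is expected to be modest, likely within or just beyond the scatter, as a 1.5-fold higher number from compound 2 to compound 3 (0.18 log units; within the scatter). Compound 3 is therefore estimated at 3 nM, within 1 nM to 12 nM.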

Compound 3, dissociation constant: 0.2 nM
Compound 3: the middle estimate sits 15-fold (1.18 log units) above what was measured; the measured number lies below the stated range.
By their numbers in this assay, from the lowest: compound 3; then compounds 1 and 2 (each within the scatter of the next).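

In this assay, propyl in place of cyano, on an aromatic carbon ortho to a large group, gives a 10-fold lower number from compound 2 to compound 3 (1.00 log units; beyond the scatter). Among the compounds shown here, this is the first step here between compounds that differ in one place, and it shows that this position can move the number beyond the scatter, towards tighter binding. Nothing given here accounts for the size of this step.

On these data alone, whether a shorter or longer chain, such as ethyl or butyl, would move the number in the same way remains open. So does the effect of an amine or a carboxylic acid at this position.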